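The source may hold more compounds than are shown below. What is called first, only, known or untested is meant among the compounds shown, and "the series" means these compounds.

In an ADME assay on Vero cells (Chlorocebus sabaeus) for cytotoxicity (on this read-out higher numbers stand for lower toxicity in this test and lower numbers for higher toxicity in this test), compound 3 `Cn1c(-c2ccc(NC(=O)CN3CCCCC3)cc2)nc2cc(C(F)(F)F)ccc21` gives only a limit, > 100000 nM. Compound 1 `O=C(O)CCC(=O)Nc1ccc(-c2nc3cc(C(F)(F)F)ccc3[nH]2)cc1` also reaches just a limit in this assay, > 100000 nM. Compound 2 `CCC(=O)Nc1ccc(-c2nc3cc(C(F)(F)F)ccc3[nH]2)cc1` likewise stops at a limit, > 100000 nM. For the measured compounds named here, the one step between measured compounds, a step that the two limits leave unreadable from compound 1 to compound 2, cannot be sized from the two values. the limit of > 100000 nM in this assay, at which 3 of the 3 values shown sit, is all the ground this assay offers. Compound 4 `O=C(CN1CCCCC1)Nc1ccc(-c2nc3cc(C(F)(F)F)ccc3[nH]2)cc1` differs from compound 3 by hydrogen in place of methyl on an aromatic nitrogen. Going by the values given here, no measured step touches a change of this kind, and the lone step, hydrogen in place of carboxy on a saturated chain carbon, has no readable size. The step to compound 4 is therefore expected to be a number no higher from compound 3 to compound 4 (the limit leaves the size open), nothing beyond the scatter. Compound 4 is expected to sit near 100000 nM, between 50000 nM and 300000 nM, most likely again as a limit.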

Compound 4, half-maximal cytotoxic concentration: 31000 nM
Compound 4: the middle estimate sits 3.2-fold (0.51 log units) above what was measured; the measured number lies below the stated range.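

Hydrogen in place of methyl on the aromatic nitrogen gives, in this assay, an at least 3.2-fold lower number from compound 3 to compound 4 (0.50 log units; beyond the scatter) with the piperidin-1-yl side chain in place, so this position can move the read-out. On the saturated chain carbon bound to a carbonyl carbon, piperidin-1-yl gives an at least 3.2-fold lower number from compound 2 to compound 4 (0.50 log units; beyond the scatter) in place of methyl and an at least 3.2-fold lower number from compound 1 to compound 4 (0.50 log units; beyond the scatter) in place of carboxymethyl, so the lower number also depends on that chain group. On these data alone, these sizes remain open-ended because one end of each step is a limit: the limit of > 100000 nM in this assay, at which 3 of the 4 values shown sit.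

The compounds shown leave open whether morpholine or dimethylamino in place of piperidin-1-yl would give a similar number. They also leave open how ethyl on the aromatic nitrogen would compare.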